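Aryl swap on the shared core, towards compound 3

The source may hold more compounds than are shown below. What is called first, only, known or untested is meant among the compounds shown, and "the series" means these compounds.

In an ADME assay (liver) for metabolic stability, with Liver microsome (Rattus norvegicus) as the target, using microsomes and NADPH, with a stated time of 30 min, tested at 1 uM (a higher number here means faster removal of the compound, a lower number slower removal), compound 1 `Nc1ccc(S(=O)(=O)N2CCN(c3ncc(C(O)(C(F)(F)F)C(F)(F)F)cc3-c3ccoc3)CC2)cn1` gives 57 mL.min-1.g-1 and compound 2 `Nc1ccc(S(=O)(=O)N2CCN(c3ncc(C(O)(C(F)(F)F)C(F)(F)F)cc3-c3cnccc3F)CC2)cn1` gives 22 mL.min-1.g-1. Within the data shown here, compound 2 therefore holds the lower of the two numbers so far.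

Compound 3 `Cc1ccc(-c2cc(C(O)(C(F)(F)F)C(F)(F)F)cnc2N2CCN(S(=O)(=O)c3ccc(N)nc3)CC2)cn1` has not yet been measured. It keeps the shared core and changes one group: 6-methylpyridin-3-yl in place of 4-fluoropyridin-3-yl on an aromatic carbon. This puts 6-methylpyridin-3-yl in place of 4-fluoropyridin-3-yl on an aromatic carbon, ortho to a large group.

Among the measured compounds shown here, only one measured step bears on this place: a 2.6-fold lower number from compound 1 to compound 2 (0.41 log units; beyond the scatter). It is modest, and it came with 4-fluoropyridin-3-yl replacing furan-3-yl. For the measured compounds named here, this single pair shows that the number can move with the group here, but no measured compound carries 6-methylpyridin-3-yl, so direction remains a judgement. With compound 2 at 22 mL.min-1.g-1, the lower end of a very short series, a rise is thought likelier than a further fall. The expected step is a 1.6-fold higher number from compound 2 to compound 3 (0.20 log units; within the scatter). In this assay the estimated value for compound 3 is 35 mL.min-1.g-1, with an expected range of 16 mL.min-1.g-1 to 75 mL.min-1.g-1.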

Compound 3, intrinsic clearance in microsomes: 182 mL.min-1.g-1
Compound 3: the middle estimate sits 5.2-fold (0.72 log units) below what was measured; the measured number lies above the stated range.
By their numbers in this assay, from the lowest: compound 2; then compound 1; then compound 3.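

In this assay, the change from 4-fluoropyridin-3-yl to 6-methylpyridin-3-yl gives an 8.3-fold higher number from compound 2 to compound 3 (0.92 log units; beyond the scatter) and so shows that this place on the shared core responds strongly to a swap between two groups with the same heavy-atom total, the same kind of six-membered aromatic ring and the same donor and acceptor counts. Measured against furan-3-yl, the same group gives a 3.2-fold higher number from compound 1 to compound 3 (0.50 log units; beyond the scatter) and leaves compound 3 with the highest number of the three, so compound 1, with its furan-3-yl group, falls between the two pyridine-containing compounds and the presence of a pyridine ring alone does not order the series. Nothing available here on the compounds' properties or on how they are cleared accounts for these differences.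

The three compounds do not separate a rise brought by the methyl group from a fall brought by the fluorine, and a pyridin-3-yl group carrying neither would be needed to tell those apart. On these data alone, how a methoxy group or a primary amine on the same ring would behave also remains open.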